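Swapping trifluoromethyl for methyl on an aryl ether

A few compounds are considered here, and "the series" means these few. Any claim that something is new, unique, unknown or untested is made for them only; others in the source may bear on it.

Measured compounds:
compound 1 `Cc1c(C(=O)NCCCN2CCN(C)CC2)c(-c2cccc(N3CCN(c4ccc(NS(=O)(=O)c5cccc(OC(F)(F)F)c5)cc4)CC3)c2)c(-c2ccc(Cl)cc2)n1C` gives 197 nM in an assay for binding affinity to Apoptosis regulator Bcl-2 (Homo sapiens), read by fluorescence polarization, with a stated time of 2 h; on this read-out lower numbers stand for stronger inhibition and higher numbers for weaker inhibition
compound 2 `Cc1c(C(=O)O)c(-c2cccc(N3CCN(c4ccc(NS(=O)(=O)c5ccc(N[C@H](CCN6CCC(O)CC6)CSc6ccccc6)c(S(=O)(=O)C(F)(F)F)c5)cc4)CC3)c2)c(-c2ccc(Cl)cc2)n1C(C)C` gives 0.8 nM in this assay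

Of the two measured compounds, compound 1 has the higher number, and the gap to compound 2 lies beyond the scatter. Compound 3 `COc1cccc(S(=O)(=O)Nc2ccc(N3CCN(c4cccc(-c5c(C(=O)NCCCN6CCN(C)CC6)c(C)n(C)c5-c5ccc(Cl)cc5)c4)CC3)cc2)c1` is not yet measured. It differs from compound 1 only by methyl in place of trifluoromethyl on an oxygen on an aromatic ring. The step from compound 1 to compound 3 is expected to be small, with no clear direction beyond the scatter, as a 1.3-fold higher number from compound 1 to compound 3 (0.10 log units; within the scatter). Compound 3 is therefore estimated at 250 nM, with a range from 100 nM to 650 nM.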

Compound 3, inhibition constant: 207 nM
Compound 3: the middle estimate sits 1.2-fold (0.08 log units) above what was measured; measured number inside the range.
By their numbers in this assay, from the lowest: compound 2; then compounds 1 and 3 (each within the scatter of the next).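

In this assay putting methyl in place of trifluoromethyl on the oxygen gives a 1.1-fold higher number from compound 1 to compound 3 (0.02 log units; within the scatter) on the core of compound 1. Trading trifluoromethoxy for methoxy here, with its loss of all three fluorines, therefore does not separate the two compounds on this read-out. Nothing at hand explains this result.

Both groups tested at this position are ethers. On these data alone, whether the number moves with a hydroxyl group, an amine or a longer chain such as ethoxy at this place stays open.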